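The source may report more compounds than this note shows. Statements on the series, on what has been measured and on what is new or still open speak of the compounds shown alone.

Values in a functional assay on the whole organism (strain albino) with Rattus norvegicus as the target, in the maximal electroshock model, with a stated time of 1 h, at a dose of 30 mg/kg by the intraperitoneal route (on this read-out lower numbers stand for less inhibition and higher numbers for more inhibition at the one dose given (going by the name of the read-out)), for the measured members of the series:

compound 1 `COc1cccc(C2SCC(=O)N2c2nnc(CNn3c(C)nc4ccccc4c3=O)s2)c1`: 60%
compound 2 `Cc1nc2ccccc2c(=O)n1NCc1nnc(N2C(=O)CSC2c2ccc(O)cc2)s1`: 60%
compound 3 `Cc1nc2ccc(Br)cc2c(=O)n1NCc1nnc(N2C(=O)CSC2c2ccccc2)s1`: 60%

Compound 3 stands level with compound 1 and compound 2 at the digits shown; its nearest neighbour by value is compound 1 and its furthest is compound 2, and neither gap reaches beyond the scatter. Among the compounds with values here, the one step measured, no change at the digits printed from compound 1 to compound 2 (within the scatter), exchanges the aryl group on the saturated ring carbon and leaves the read-out unchanged within the scatter.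

Compound 4 `Cc1nc2ccccc2c(=O)n1NCc1nnc(N2C(=O)CSC2c2ccccc2)s1` is the unmeasured member. It differs from compound 3 by hydrogen in place of bromo on an aromatic carbon. Within the data shown here, no measured step touches the fused ring system, so nothing directly bears on the removal of bromo; the only indirect guide is that the one change tried so far, from compound 1 to compound 2, produced no shift, and that all three measured compounds sit at one level.

On that basis no step beyond the scatter is expected from compound 3 to compound 4, so that no change at the digits printed from compound 3 to compound 4 (within the scatter) is the expected change. Compound 4 is therefore estimated at 60% in this assay, with a range from 45% to 75%.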

Compound 4, a percentage reported as inhibition, in the whole organism at one dose (the size of the read-out at that dose, not a potency): 60%
The estimate for compound 4 equals the measured number at the digits printed, within the range that was stated.
By their numbers in this assay, from the lowest: compounds 1, 2, 3 and 4 (each within the scatter of the next).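

In this assay, within the data shown here, hydrogen in place of bromo on the aromatic carbon of the fused system gives no change at the digits printed from compound 3 to compound 4 (within the scatter) and is the only measured step at this part of the molecule, so at this one dose the read-out does not separate bromo from hydrogen at this position. Compound 4 also supplies the unsubstituted phenyl comparison for the aryl group on the saturated ring carbon: hydrogen in place of hydroxy gives no change at the digits printed from compound 2 to compound 4 (within the scatter) and hydrogen in place of methoxy gives no change at the digits printed from compound 1 to compound 4 (within the scatter) and so neither substituent is distinguished from hydrogen here. No accompanying data bear on why these steps show no separation.

On these data alone, because every comparison rests on a single dose, it remains open whether these four compounds would separate at another dose or in a potency measure. Also open, as far as these compounds go, is the outcome with a group of a different kind on either aromatic ring, such as an amine or a carboxylic acid in place of bromo on the fused system, or a longer alkoxy chain in place of methoxy on the phenyl ring.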